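From 4-Methoxybenzyl to 3,4-Dimethoxybenzyl

This account rests on a few compounds, and the source may have more. Where it says the series, first, only, none or still open, it means among the compounds named here.

Compound 1 `COc1ccc(Oc2ccc3cc(NC(=O)c4ccc(O)c(CC=C(C)C)c4)c(=O)oc3c2C)cc1` gives 42700 nM in a functional assay on SK-BR-3 cells (Homo sapiens) for antiproliferative activity; a lower number here means a stronger inhibitor, a higher number a weaker inhibitor. Compound 2 `COc1ccc(Nc2ccc3cc(NC(=O)c4ccc(O)c(CC=C(C)C)c4)c(=O)oc3c2C)cc1` reaches only a limit of this assay, > 100000 nM. Compound 3 `COc1ccc(Cc2ccc3cc(NC(=O)c4ccc(O)c(CC=C(C)C)c4)c(=O)oc3c2C)cc1` gives 11100 nM.

Among the two numbers shown, compound 3 has the lowest; its nearest neighbour is compound 1, with a 3.8-fold lower number from compound 1 to compound 3 (0.59 log units; beyond the scatter). Compound 4 `COc1ccc(Cc2ccc3cc(NC(=O)c4ccc(O)c(CC=C(C)C)c4)c(=O)oc3c2C)cc1OC` differs from compound 3 by methoxy in place of hydrogen on an aromatic carbon. The measured steps all change the link between the two aromatic parts rather than the substitution of the outer ring: an at least 2.3-fold higher number from compound 1 to compound 2 (0.36 log units; beyond the scatter), a 3.8-fold lower number from compound 1 to compound 3 (0.59 log units; beyond the scatter) and an at least 9.0-fold lower number from compound 2 to compound 3 (0.95 log units; beyond the scatter). None of them tests an added methoxy group, so they offer no direct guide. The expected step of a 1.1-fold lower number from compound 3 to compound 4 (0.05 log units; within the scatter) is therefore small, not clearly beyond the scatter. Compound 4 is estimated at 10000 nM, within 3500 nM to 30000 nM.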

Compound 4, half-maximal inhibitory concentration: > 100000 nM
Compound 4 gave a limit, no number; the forecaster's own chance of this, stated with the estimate: 3%; middle value at least 10-fold (1.00 log units) away from the limit.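

In this assay compound 4 gives > 100000 nM, which is a limit of the assay and not a number. This is the first change to the outer ring among these compounds, and one added methoxy, ortho to the existing methoxy group, matters: an at least 9.0-fold higher number from compound 3 to compound 4 (0.95 log units; beyond the scatter), and an at least 2.3-fold higher number from compound 1 to compound 4 (0.36 log units; beyond the scatter). The step between compound 2 and compound 4 cannot be read: the limit of > 100000 nM in this assay, at which 2 of the 4 values shown sit.

Going by these compounds, it remains open whether a hydroxy group or a fluorine atom at this position would keep the activity of compound 3. Also open, on these data alone, is how far above the limit compound 4 really lies.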